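A few compounds are considered here, and "the series" means these few. Any claim that something is new, unique, unknown or untested is made for them only; others in the source may bear on it.

The series shares one core, shown in compound 3, `COc1ccc(C[C@H]2COC(=O)[C@@H]2Cc2ccc(OC(=O)CCC(=O)N3CCCCC3)c(OC)c2)cc1OC`, and its companions. In an ADME assay on HeLa cells (Homo sapiens) for cytotoxicity, read by MTT assay (a lower number here means a stronger inhibitor, a higher number a weaker inhibitor), compound 3 gives 128000 nM, the lowest of the two numbers recorded there. For the measured compounds named here, compound 2, `COc1ccc(C[C@H]2COC(=O)[C@@H]2Cc2ccc(OC(=O)CCC(=O)N3CCCC3)c(OC)c2)cc1OC`, gives 201000 nM in this assay, and the only step seen so far, a 1.6-fold lower number from compound 2 to compound 3 (0.20 log units; within the scatter), lies within the scatter. Compound 1, `COC(=O)[C@@H](NC(=O)CCC(=O)Oc1ccc(C[C@H]2C(=O)OC[C@@H]2Cc2ccc(OC)c(OC)c2)cc1OC)c1c[nH]c2ccccc12`, is recorded in this assay only as a limit, >= 600000 nM, and that is all it shows, (the limit of >= 600000 nM in this assay, at which 1 of the 3 values shown sits).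

Compound 4, `COC(=O)[C@@H](NC(=O)CCC(=O)Oc1ccc(C[C@H]2C(=O)OC[C@@H]2Cc2ccc(OC)c(OC)c2)cc1OC)C(C)C`, has not yet been measured. It differs from compound 3 by (1-(methoxycarbonyl)-2-methylpropyl)amino in place of piperidin-1-yl on a carbonyl carbon. Going by the values given here, no measured step covers this change directly; the only step at hand is the one between compound 2 and compound 3, which stayed within the scatter. Compound 1 carries a related (methoxycarbonyl)alkylamino group at the same carbonyl carbon and sits at the limit, so compound 4 is expected to move toward weaker inhibition, with an estimated step of a 2.7-fold higher number from compound 3 to compound 4 (0.44 log units; beyond the scatter). In this assay compound 4 is therefore expected to give about 350000 nM, in the range 120000 nM to 700000 nM.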

Compound 4, half-maximal inhibitory concentration: 64000 nM
Compound 4: the middle estimate sits 5.5-fold (0.74 log units) above what was measured; measured number below the stated range.
By their numbers in this assay, from the lowest: compounds 4, 3 and 2 (each within the scatter of the next, the first and the last beyond it). At a limit, above all of these: compound 1.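

At this carbonyl carbon, the open-chain (1-(methoxycarbonyl)-2-methylpropyl)amino group does not raise the number in this assay as the limit for compound 1 had suggested: in place of piperidin-1-yl it gives a 2.0-fold lower number from compound 3 to compound 4 (0.30 log units; within the scatter), and in place of pyrrolidin-1-yl it gives a 3.1-fold lower number from compound 2 to compound 4 (0.50 log units; beyond the scatter). For the compounds shown here, the group on the saturated chain carbon counts for more than the earlier compounds could show, since isopropyl in place of 1H-indol-3-yl gives an at least 9.3-fold lower number from compound 1 to compound 4 (0.97 log units; beyond the scatter). Compound 1 still stands only as a limit, not a number: the limit of >= 600000 nM in this assay, at which 1 of the 4 values shown sits.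

The compounds shown leave open how a carboxylic acid in place of the methyl ester would read in this assay. They also leave open whether a methyl or benzyl group on that chain carbon would fall nearer compound 4 or compound 1.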